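Spiro-hydantoin amide series: step to compound 3

This account rests on a few compounds, and the source may have more. Where it says the series, first, only, none or still open, it means among the compounds named here.

Measured compounds
compound 1, `CCc1nn(CC)c(C2CCN(C(=O)CN3CN(c4ccccc4)C4(CCN(C(=O)c5ccc(C6CCCCC6)cc5)CC4)C3=O)CC2)c1C` — "not determined" (no result reported)
compound 2, `CC(C)(C)OC(=O)NCCCNC(=O)CN1CN(c2ccccc2)C2(CCN(C(=O)c3ccc(C4CCCCC4)cc3)CC2)C1=O` — 6000 nM

Within the data shown here, compound 2 carries the only number in this set: in an assay on HEK293 cells for displacement of a labelled ligand from NPC1-like intracellular cholesterol transporter 1 (Homo sapiens) (on this read-out lower numbers stand for stronger inhibition and higher numbers for weaker inhibition), compound 2 gives 6000 nM; for compound 1 the entry in this assay is "not determined" (no result reported). Compound 3, `O=C(CN1CN(c2ccccc2)C2(CCN(C(=O)c3ccc(C4CCCCC4)cc3)CC2)C1=O)N1CCC(CO)CC1`, is not yet measured. It differs from compound 2 by 4-(hydroxymethyl)piperidin-1-yl in place of (3-((tert-butoxycarbonyl)amino)propyl)amino on a carbonyl carbon. Among the measured compounds shown here, with no measured step available, the expectation for this assay is a change from compound 2 to compound 3 of a 1.5-fold lower number from compound 2 to compound 3 (0.18 log units; within the scatter), within the scatter or slightly towards stronger inhibition. The estimate for compound 3 is 4000 nM, with a range from 1000 nM to 20000 nM.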

Compound 3, half-maximal inhibitory concentration: 1100 nM
Compound 3: middle estimate off by 3.6-fold (0.56 log units), on the high side; the range from low to high includes it.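

In this assay, the group on the carbonyl carbon proves able to move the read-out: 4-(hydroxymethyl)piperidin-1-yl in place of (3-((tert-butoxycarbonyl)amino)propyl)amino gives a 5.5-fold lower number from compound 2 to compound 3 (0.74 log units; beyond the scatter). The open chain with its tert-butoxycarbonyl end is therefore not required for the number seen with compound 2. No measurement shown bears on the reason for this shift.

The step exchanges the chain, the tert-butoxycarbonyl group and the hydroxymethyl-bearing ring together, so their separate contributions remain unresolved. Also open, on these data alone, is how plain piperidin-1-yl or 4-(aminomethyl)piperidin-1-yl would read at this position.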